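The source may report more compounds than this note shows. Statements on the series, on what has been measured and on what is new or still open speak of the compounds shown alone.

Compound 3, `COc1cc(-c2ncnn2-c2ccc([N+](=O)[O-])cc2)cc(OC)c1OC`, carries a nitro group on the ring that sits on the aromatic nitrogen of the shared core. In a functional assay on K562 cells (Homo sapiens) for antiproliferative activity, read by MTT assay, with a stated time of 72 h (a higher number here means a weaker inhibitor, a lower number a stronger inhibitor), compound 3 gives > 10000 nM, which is a limit of the assay and not a number. Its two companions stand no differently. Compound 1, `COc1cc(-c2ncnn2-c2ccc(Cl)c(Cl)c2)cc(OC)c1OC`, gives in this assay > 10000 nM, again a limit. Compound 2, `COc1cc(-c2ncnn2-c2ccc(Cl)cc2Cl)cc(OC)c1OC`, gives in this assay > 10000 nM, also a limit. For the measured compounds named here, the one change that joins two measured compounds, a step that the two limits leave unreadable from compound 1 to compound 2, therefore has no readable size. What the measured compounds show is summed up by the limit of > 10000 nM in this assay, at which 3 of the 3 values shown sit: every value sits where the assay stops counting, and nothing reveals how far beyond it any of them lies.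

Compound 4, `COc1cc(-c2ncnn2-c2ccc(N)cc2)cc(OC)c1OC`, differs from compound 3 by amino in place of nitro on an aromatic carbon. Going by the values given here, no measured step touches this change, and none of the three values gives a number to move from. Compound 3 stands at the limit, and the measured steps leave nothing to suggest a direction for the amino compound. The step is therefore expected to be a step that the limit leaves unreadable from compound 3 to compound 4, with compound 4 most likely ending at the same limit. Compound 4 is estimated at 12000 nM, with a range from 3000 nM to 50000 nM.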

Compound 4, half-maximal inhibitory concentration: > 10000 nM
Compound 4: no number, only a limit; the forecaster's own chance of this, stated with the estimate: 70%; the middle value lies beyond the limit too.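

For the compounds shown here, compound 4 also gives a limit and not a number, and no step among compound 1, compound 2, compound 3 and compound 4 can be read in this assay. The series now stands as follows: the limit of > 10000 nM in this assay, at which 4 of the 4 values shown sit. The compounds shown leave open how far beyond the limit each one lies, and whether any group on the ring on the aromatic nitrogen would give a readable value.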